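Permeability notes: aryloxy versus alkyl at the fused ring

This account rests on a few compounds, and the source may have more. Where it says the series, first, only, none or still open, it means among the compounds named here.

Measured compounds, in an ADME assay for permeability, using PAMPA, with a stated time of 30 min, at pH 7.4; on this read-out higher numbers stand for higher permeability and lower numbers for lower permeability:
- compound 1 `COc1ccc(F)cc1CNCCCNc1ccnc2cc(CCc3ccccc3)ccc12`: 23 10^-6 cm/s
- compound 2 `COc1ccc(F)cc1CNCCCNc1ccnc2cc(Oc3ccc(C(C)(C)C)cc3)ccc12`: 317 10^-6 cm/s
- compound 3 `CCC(CC)c1ccc2c(NCCCNCc3cc(F)ccc3OC)ccnc2c1`: 23 10^-6 cm/s

Compound 3 stands level with compound 1 at the digits printed, the two together at the bottom of the three numbers; compound 2 sits well above, the gap being a 14-fold lower number from compound 2 to compound 3 (1.14 log units; beyond the scatter).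

Compound 4 `COc1ccc(F)cc1CNCCCNc1ccnc2cc(Oc3cccc(N(C)C)c3)ccc12` is the next analogue, not yet measured in this assay. It differs from compound 3 as follows: 3-(dimethylamino)phenoxy in place of pentan-3-yl on an aromatic carbon.

Within the data shown here, two measured steps bear on this change. Replacing phenethyl by 4-(tert-butyl)phenoxy gave a 14-fold higher number from compound 1 to compound 2 (1.14 log units; beyond the scatter), and moving from that aryloxy to pentan-3-yl gave a 14-fold lower number from compound 2 to compound 3 (1.14 log units; beyond the scatter); the step from phenethyl to pentan-3-yl, no change at the digits printed from compound 1 to compound 3 (within the scatter), was within the scatter. The change into compound 4 runs in the same direction as the reverse of compound 2 to compound 3, an aryloxy group entering where an alkyl leaves. The aryloxy of compound 4 carries 3-(dimethylamino) rather than 4-(tert-butyl), for which no comparison exists in the set, so the size of the rise is less certain than its direction. A large increase beyond the scatter is expected, with the step for compound 4 estimated as a 6.5-fold higher number from compound 3 to compound 4 (0.81 log units; beyond the scatter) because compound 2 gives 317 10^-6 cm/s. Compound 4 is expected to give about 150 10^-6 cm/s, within 50 10^-6 cm/s to 400 10^-6 cm/s.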

Compound 4, apparent permeability: 317 10^-6 cm/s
Compound 4: middle estimate off by 2.1-fold (0.32 log units), on the low side; the range from low to high includes it.
By their numbers in this assay, from the lowest: compounds 1 and 3 (each within the scatter of the next); then compounds 2 and 4 (each within the scatter of the next).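

Working notes on the series. In this assay, the high reading at this aromatic carbon of the shared core no longer rests on the 4-(tert-butyl)phenoxy group alone: a second aryloxy group, 3-(dimethylamino)phenoxy, stands well clear of both the pentan-3-yl (a 14-fold higher number from compound 3 to compound 4 (1.14 log units; beyond the scatter)) and the phenethyl (a 14-fold higher number from compound 1 to compound 4 (1.14 log units; beyond the scatter)). Among the four compounds, both aryloxy groups sit in the upper pair and both carbon-linked groups in the lower pair, with no compound going against that split. The outer ring also tolerated a change in both the identity and the placing of its substituent, from 4-(tert-butyl) to 3-(dimethylamino), without a readable difference (no change at the digits printed from compound 2 to compound 4 (within the scatter)); no measurement in hand explains any of these steps.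

The compounds shown do not separate the contribution of the ether oxygen from that of the outer aromatic ring, a question that a directly attached phenyl or a benzyloxy group at this carbon would address. They also leave open whether the reading holds for an outer ring bearing a carboxylic acid or a primary amine.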